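Replacing a Pyrrole with a Hydroxyphenyl Group

This account rests on a few compounds, and the source may have more. Where it says the series, first, only, none or still open, it means among the compounds named here.

Compound 1, `Cn1cccc1C(=O)/C=C/c1ccc2c(c1)B(O)OC2`, reaches in a toxicity assay on MCF-10A cells (Homo sapiens) for cytotoxicity, read by MTT assay, with a stated time of 48 h (a higher number here means a weaker inhibitor, a lower number a stronger inhibitor), only the assay limit of > 100000 nM.
Compound 2, `Cc1ccc(C(=O)/C=C/c2ccc3c(c2)B(O)OC3)cc1`, gives in this assay a value of 8300 nM.
Compound 3, `O=C(/C=C/c1ccc2c(c1)B(O)OC2)c1ccc(OCc2ccccc2)cc1`, gives in this assay a value of 23300 nM.

All three share the same core bearing a carbonyl and a double bond; they differ only in the group attached to the carbonyl carbon. Compound 1 stands at the weakest end, since its result is a limit of the assay rather than a number, as the limit of > 100000 nM in this assay, at which 1 of the 3 values shown sits, records.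

The unmeasured compound 4, `O=C(/C=C/c1ccc2c(c1)B(O)OC2)c1ccc(O)cc1`, differs from compound 1 as follows: 4-hydroxyphenyl in place of 1-methyl-1H-pyrrol-2-yl on a carbonyl carbon.

For the measured compounds named here, two measured steps bear on this change. The first, an at least 12-fold lower number from compound 1 to compound 2 (1.08 log units; beyond the scatter), shows that exchanging the pyrrole for a plain six-membered carbon ring brings the number down sharply. The second, a 2.8-fold higher number from compound 2 to compound 3 (0.45 log units; beyond the scatter), shows that a larger oxygen-bearing substituent on that ring pushes the number back up somewhat. Compound 4 carries an oxygen on the ring, so a step downward from compound 1 is expected, but landing between compound 2 and compound 3 or a little above compound 3.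

The estimate for compound 4 is therefore 20000 nM, with a range from 6000 nM to 70000 nM, which corresponds to the expected step of an at least 5.0-fold lower number from compound 1 to compound 4 (0.69 log units; beyond the scatter).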

Compound 4, half-maximal inhibitory concentration: 24800 nM
Compound 4: middle estimate off by 1.2-fold (0.09 log units), on the low side, and the stated range covers the measured number.
By their numbers in this assay, from the lowest: compound 2; then compounds 3 and 4 (each within the scatter of the next). At a limit, above all of these: compound 1.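

Taking the benzyl off the oxygen changes nothing that can be told apart in this assay: a 1.1-fold higher number from compound 3 to compound 4 (0.03 log units; within the scatter). At this place on the ring, then, the free hydroxy group and the much larger benzyloxy group read alike, so the rise seen with benzyloxy does not depend on the benzyl part, and the oxygen-bearing compounds 3 and 4 both differ from the methyl-bearing compound 2, as the step for hydroxy in place of methyl also shows: a 3.0-fold higher number from compound 2 to compound 4 (0.48 log units; beyond the scatter). The swap of 1-methyl-1H-pyrrol-2-yl for 4-hydroxyphenyl on the carbonyl carbon still lowers the number, an at least 4.0-fold lower number from compound 1 to compound 4 (0.60 log units; beyond the scatter), but the full size of that step stays unknown, as compound 1 stands at a limit and not at a number: the limit of > 100000 nM in this assay, at which 1 of the 4 values shown sits.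

Going by these compounds, only methyl, hydroxy and benzyloxy appear on this six-membered ring, so it remains open whether a methoxy group, an amine or a carboxylic acid at the same place would read like the oxygen-bearing pair or like methyl. A phenyl ring carrying only hydrogen at that place is also absent, which leaves the contribution of the ring itself apart from its substituent unresolved.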